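A Second Anilino Substituent Swap on the Shared Core

The source may report more compounds than this note shows. Statements on the series, on what has been measured and on what is new or still open speak of the compounds shown alone.

compound 1 `CCS(=O)(=O)Nc1cc(-c2ccc3ncnc(Nc4cccc(F)c4)c3c2)cnc1OC`: 9940 nM
compound 2 `CCS(=O)(=O)Nc1cc(-c2ccc3ncnc(Nc4ccc(OC(F)(F)F)cc4)c3c2)cnc1OC`: 25400 nM

In a functional assay on A549 cells (Homo sapiens) for cytotoxicity, read by sulforhodamine B assay, with a stated time of 72 h (on this read-out lower numbers stand for stronger inhibition and higher numbers for weaker inhibition), compound 2 stands highest of the two numbers, with compound 1 nearest: a 2.6-fold higher number from compound 1 to compound 2 (0.41 log units; beyond the scatter). Compound 3 `CCS(=O)(=O)Nc1cc(-c2ccc3ncnc(Nc4ccc(OC)c(Cl)c4)c3c2)cnc1OC` differs from compound 2 by 3-chloro-4-methoxyphenyl in place of 4-(trifluoromethoxy)phenyl on a nitrogen on an aromatic ring. For the measured compounds named here, the only measured step at this nitrogen, a 2.6-fold higher number from compound 1 to compound 2 (0.41 log units; beyond the scatter), was modest, and no measured pair covers this exact exchange, so a small movement, leaning toward a lower number as for compound 1 at 9940 nM, is expected. Compound 3 is expected near 15000 nM, within 5000 nM to 45000 nM. The expected step is a 1.7-fold lower number from compound 2 to compound 3 (0.23 log units; within the scatter).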

Compound 3, half-maximal inhibitory concentration: 5240 nM
Beside the measured number, compound 3's estimate is 2.9-fold (0.46 log units) above it; low and high end bracket the measured number.
By their numbers in this assay, from the lowest: compounds 3 and 1 (each within the scatter of the next); then compound 2.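

In this assay, the group on this nitrogen can also bring the number down: 3-chloro-4-methoxyphenyl in place of 4-(trifluoromethoxy)phenyl gives a clear step (a 4.8-fold lower number from compound 2 to compound 3 (0.69 log units; beyond the scatter)). Against 3-fluorophenyl, the same group does not separate from the earlier compound (a 1.9-fold lower number from compound 1 to compound 3 (0.28 log units; within the scatter)), so among these three only compound 2 stands apart. No evidence is available to explain this result. The compounds shown leave open how an amine or a carboxylic acid on this phenyl ring would change the number.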